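Swapping a dichlorophenyl for a fluorophenyl on the ether arm

The compounds below may be only part of what the source reports. "The series", "measured", "known", "first", "only" and "open" are said of these compounds alone.

The three compounds here share one core, a diaminotriazine spiro-fused to an oxygen-containing saturated ring, with an aryloxypropyl chain hanging from a ring nitrogen through an oxygen. Compound 1 `NC1=NC2(CCOCC2)N(OCCCOc2ccccc2)C(N)=N1` carries a plain phenyl at the end of that chain; in an assay on isolated protein for inhibition of Dihydrofolate reductase (Homo sapiens), read by spectrophotometry, using NADPH, with stated times of 5 s and 6 min (a lower number here means a stronger inhibitor, a higher number a weaker inhibitor), compound 1 gives 86.1 nM. Compound 2 `NC1=NC2(CCOCC2)N(OCCCOc2cccc(Cl)c2Cl)C(N)=N1` carries a 2,3-dichlorophenyl instead, but for compound 2 in this assay the result stands as "not determined" (no result reported), so compound 2 has no number to anchor it, and nothing can be said of how it compares with compound 1.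

Compound 3 `NC1=NC2(CCOCC2)N(OCCCOc2ccc(F)cc2)C(N)=N1` is the next member. Relative to compound 2 the change is 4-fluorophenyl in place of 2,3-dichlorophenyl on an oxygen on a saturated carbon. Among the compounds with values here, with no value for compound 2, the only foothold is compound 1, which differs from compound 3 solely by the single fluorine. Such a small change, between two compounds as close as compound 1 and compound 3, is expected to move this assay little, most likely by no more than the usual scatter and in no firm direction. Compound 3 is therefore estimated at 90 nM, with a plausible range from 30 nM to 300 nM.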

Compound 3, half-maximal inhibitory concentration: 46.6 nM
The estimate for compound 3 lay 1.9-fold (0.29 log units) above the measured number; measured number inside the range.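

In this assay, fluoro in place of hydrogen on an aromatic carbon gives a 1.8-fold lower number from compound 1 to compound 3 (0.27 log units; within the scatter) and so cannot be told apart from repeat measurements of one compound. Within this one pair, then, a 4-fluorophenyl serves as well as a plain phenyl, which the earlier compounds could not show, since compound 2 has no number and any step involving it cannot be read. What the 2,3-dichlorophenyl of compound 2 does therefore stays unknown, and nothing shown here offers a measured explanation for the result.

The compounds shown leave open whether a larger group on the same phenyl ring, such as a methoxy, a trifluoromethyl or a single chlorine, would move the number beyond the scatter, or whether this ring accepts such groups just as readily as it accepts the fluorine. They also leave open how the number would respond to changes in the arm itself, such as a longer chain carrying the same phenyl, or an amine or a carboxylic acid in place of the phenyl.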